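The source may hold more compounds than are shown below. What is called first, only, known or untested is meant among the compounds shown, and "the series" means these compounds.

Working notes on the series, all in an assay on isolated protein for displacement of a labelled ligand from Type-2 angiotensin II receptor (Homo sapiens), with a stated time of 180 min; on this read-out lower numbers stand for stronger inhibition and higher numbers for weaker inhibition.

Two compounds carry measured numbers. Compound 1 `CCCCNC(=O)c1cc(C)c2nc(CCC)n(Cc3ccc(-c4ccccc4C(=O)O)cc3)c2c1` gives 164 nM in this assay. Within the data shown here, compound 2 `CCCc1nc2c(C)cc(C(=O)N3CCCCC3)cc2n1Cc1ccc(-c2ccccc2C(=O)O)cc1` gives 42 nM and so stands lowest of the two; the only step to it, a 3.9-fold lower number from compound 1 to compound 2 (0.59 log units; beyond the scatter), exchanges a butylamino for a piperidin-1-yl on the carbonyl carbon and lies beyond the scatter.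

Compound 3 `CCCc1nc2c(C)cc(C(=O)Nc3ccc(C)cc3)cc2n1Cc1ccc(-c2ccccc2C(=O)O)cc1` is not yet measured. It differs from compound 2 by (4-methylphenyl)amino in place of piperidin-1-yl on a carbonyl carbon. Among the measured compounds shown here, no measured step covers this exchange directly; the only step that bears on the same carbonyl carbon is a 3.9-fold lower number from compound 1 to compound 2 (0.59 log units; beyond the scatter), which went from a butylamino with an amide hydrogen to a piperidin-1-yl without one. Compound 3 again carries an amide hydrogen, so a modest move back toward a higher number is expected, with wide uncertainty, as a 1.9-fold higher number from compound 2 to compound 3 (0.28 log units; within the scatter). For compound 3 the expected value is 80 nM, within the range 25 nM to 250 nM.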

Compound 3, half-maximal inhibitory concentration: 61 nM
Compound 3: middle estimate off by 1.3-fold (0.12 log units), on the high side; the measured number falls inside the stated range.
By their numbers in this assay, from the lowest: compounds 2 and 3 (each within the scatter of the next); then compound 1.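

On the carbonyl carbon, an aryl amide with an amide hydrogen holds up as well as the piperidine amide without one: a 1.5-fold higher number from compound 2 to compound 3 (0.16 log units; within the scatter) stays within the scatter. Changing only the group on the amide nitrogen gives a 2.7-fold lower number from compound 1 to compound 3 (0.43 log units; beyond the scatter), so butyl and 4-methylphenyl separate even though both compounds keep the amide hydrogen. Across these three compounds, the amide hydrogen alone therefore does not track with the number, and compound 3 goes against any such reading. No evidence in hand accounts for these differences.

Still open, on these data alone, is what phenylamino, lacking the ring methyl, would give at this carbonyl carbon. Equally open, as far as these compounds go, is whether N-methyl-(4-methylphenyl)amino, which keeps the aryl ring and replaces the amide hydrogen with methyl, would stay with compound 3 and compound 2.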